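The source may hold more compounds than are shown below. What is called first, only, known or untested is meant among the compounds shown, and "the series" means these compounds.

Three compounds have been measured in an assay for inhibition of Nitric oxide synthase, inducible (Homo sapiens), with a stated time of 30 min, tested at 1 mM; on this read-out higher numbers stand for more inhibition at the one concentration tested (going by the name of the read-out) and lower numbers for less inhibition:

Compound 1 `N=C(NCCC(O)c1ccccc1N)c1ccccc1` gives 64.1%.
Compound 2 `N=C(NCCC(O)c1ccccc1N)c1ccc(Cl)cc1` gives 73.2%.
Compound 3 `COc1ccc(N)c(C(=O)CCNC(=N)c2ccccc2)c1` gives 94.7%.

Compound 1 and compound 2 share one core and differ only by chloro in place of hydrogen on an aromatic carbon. That change made a number 9.1 percentage points higher from compound 1 to compound 2 (within the scatter). Compound 3 is built on a different core; the difference between the two cores is not broken down here. Compound 4 `COc1ccc(N)c(C(=O)CCNC(=N)c2ccc(Cl)cc2)c1` has not yet been measured and stands to compound 3 exactly as compound 2 stands to compound 1: the same change, (chloro in place of hydrogen on an aromatic carbon), at the same place. In this assay compound 4 is therefore expected to give 96%, somewhere between 88% and 100%, because the earlier instance of this change gave a number 9.1 percentage points higher from compound 1 to compound 2 (within the scatter) and compound 3 already sits near the top of the scale. That amounts to an expected step of a number 1.3 percentage points higher from compound 3 to compound 4 (within the scatter).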

Compound 4, a percentage reported as inhibition, at one concentration (the size of the read-out at that concentration, not a potency): 75.1%
Compound 4: the middle estimate sits 20.9 percentage points above what was measured; the measured number lies below the stated range.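

In this assay, putting chloro in place of hydrogen on the core of compound 3 gave a number 19.6 percentage points lower from compound 3 to compound 4 (beyond the scatter). On these two cores, the result of this change did not carry over from one to the other: the same change on two cores in this assay, a number 9.1 percentage points higher (within the scatter) from compound 1 to compound 2 and a number 19.6 percentage points lower (beyond the scatter) from compound 3 to compound 4, 28.7 percentage points apart, beyond the scatter of two such steps This rests on a single pair for each core, tested at one concentration, so it shows that a result on one core cannot be assumed on the other, but not why the two cores differ or how the change would behave on a third core.

As far as these compounds go, it remains open whether the drop on the core of compound 3 is specific to chloro. A fluoro or bromo group at the same place could give a different answer.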